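Bromo to hydrogen on the compound 2 scaffold

This account rests on a few compounds, and the source may have more. Where it says the series, first, only, none or still open, it means among the compounds named here.

Measured in a functional assay on A549 cells (Homo sapiens) for cytotoxicity, read by WST assay, with a stated time of 48 h; on this read-out higher numbers stand for weaker inhibition and lower numbers for stronger inhibition:
- compound 1 `COc1ccc2c(/C=C(\C#N)C(=O)c3c[nH]c4cc(OC)ccc34)c[nH]c2c1`: 1700 nM
- compound 2 `N#C/C(=C\c1cn(Cc2ccc(Cl)cc2)c2ccc(Br)cc12)C(=O)c1c[nH]c2ccccc12`: 24900 nM
- compound 3 `COc1ccc2[nH]cc(C(=O)/C(C#N)=C/c3c[nH]c4cc(F)ccc34)c2c1`: > 50000 nM (a limit of the assay)

Of the two actual numbers, compound 2 at 24900 nM holds the higher and compound 1 at 1700 nM the lower. Compound 3 gives only a limit.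

Compound 4 `N#C/C(=C\c1cn(Cc2ccc(Cl)cc2)c2ccccc12)C(=O)c1c[nH]c2ccccc12` has hydrogen in place of bromo on an aromatic carbon of compound 2: hydrogen in place of bromo on an aromatic carbon. For the measured compounds named here, no measured pair differs in one place, so the expectation rests on compound 2 at 24900 nM alone. On these data alone, no step beyond the scatter is expected in this assay, and the direction stays open. The expected change is a 1.2-fold lower number from compound 2 to compound 4 (0.10 log units; within the scatter). For compound 4 the estimated value is 20000 nM, with an expected range of 7000 nM to 50000 nM.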

Compound 4, half-maximal inhibitory concentration: > 50000 nM
Compound 4: no number, only a limit; the forecaster's own chance of this, stated with the estimate: 25%; at least 2.5-fold (0.39 log units) between middle value and limit.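

Hydrogen in place of bromo on this aromatic carbon gives an at least 2.0-fold higher number from compound 2 to compound 4 (0.30 log units; that floor lies within the scatter). Compound 4 carries only a limit in this assay, so the step has a floor and no measured size, and a loss of activity on removing bromo is suggested but not established. The step stays open-ended since the result sits at the assay limit: the limit of > 50000 nM in this assay, at which 2 of the 4 values shown sit.

On these data alone, whether iodo or an amine on this same carbon would give a measurable value remains open. So does whether any such group would bring the number closer to that of compound 1, whose core differs in more than one place.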